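The source may hold more compounds than are shown below. What is called first, only, known or untested is meant among the compounds shown, and "the series" means these compounds.

Of the compounds shown here, two of one shared core have been measured in a functional assay on K562 cells (Homo sapiens) for cytotoxicity, read by MTT assay; a higher number here means a weaker inhibitor, a lower number a stronger inhibitor. Compound 1 `COc1ccc(/C=C/C(=O)c2ccc(OC)c3c2OC(C)(C)C=C3)cc1OCCCN(C)C` gives 2920 nM, and compound 2 `C=CC(=O)Oc1cc(/C=C/C(=O)c2ccc(OC)c3c2OC(C)(C)C=C3)ccc1OC` gives 300 nM, the lowest of the two numbers. For the measured compounds named here, the only measured step, a 9.7-fold lower number from compound 1 to compound 2 (0.99 log units; beyond the scatter), alters the group on the ring oxygen. Compound 3 `COc1ccc(/C=C/C(=O)c2ccc(OC)c3c2OC(C)(C)C=C3)cc1OC(=O)c1ccc(Br)cc1` instead keeps the ester and changes its far end: 4-bromophenyl in place of vinyl on a carbonyl carbon. Going by the values given here, no measured step bears directly on such a change, so no shift beyond the scatter is expected, with an estimated step of a 2.0-fold higher number from compound 2 to compound 3 (0.30 log units; within the scatter). Compound 3 is therefore estimated at 600 nM, within a range from 200 nM to 2000 nM.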

Compound 3, half-maximal inhibitory concentration: 1110 nM
For compound 3 the middle estimate is 1.9-fold (0.27 log units) below the measured one; measured number inside the range.
By their numbers in this assay, from the lowest: compound 2; then compound 3; then compound 1.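

In this assay the far end of the ester on the ring oxygen matters: the change from vinyl to 4-bromophenyl gives a 3.7-fold higher number from compound 2 to compound 3 (0.57 log units; beyond the scatter) and so costs part of what the ester gained. Even so, the bromophenyl ester keeps a lower number than the 3-(dimethylamino)propyl ether, with a 2.6-fold lower number from compound 1 to compound 3 (0.42 log units; beyond the scatter) in the same direction as the first step. Nothing available explains the size of either step. An unsubstituted phenyl would show whether the ring or the bromine goes with the change, and a saturated ethyl in place of vinyl would test the double bond. On these data alone, whether other esters fall closer to compound 2 remains open.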